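From methylsulfonyl to hydroxymethyl at the assay limit

The source may hold more compounds than are shown below. What is called first, only, known or untested is meant among the compounds shown, and "the series" means these compounds.

Compound 1 `Cc1noc(-c2nc(C)c3c(c2N)C(=O)N(Cc2ccccc2)C3=O)n1` gives < 5000 nM (a limit)
Compound 2 `Cc1noc(-c2nc(C)c3c(c2N)C(=O)N(Cc2ccc(S(C)(=O)=O)cc2)C3=O)n1` gives < 5000 nM (a limit)

In a physicochemical assay for solubility, using the shake flask method, in simulated intestinal fluid, measured as kinetic solubility, with a stated time of 2 h, at 25 degrees C, at pH 6.5 (on this read-out higher numbers stand for higher solubility and lower numbers for lower solubility), compound 2 stands only at a limit, < 5000 nM and no number. The same holds for compound 1, so the whole record amounts to the limit of < 5000 nM in this assay, at which 2 of the 2 values shown sit, and no more. Among the compounds with values here, the one measured step is a step that the two limits leave unreadable from compound 1 to compound 2 with methylsulfonyl in place of hydrogen on an aromatic carbon.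

Compound 3 `Cc1noc(-c2nc(C)c3c(c2N)C(=O)N(Cc2ccc(CO)cc2)C3=O)n1` has not been measured. It carries hydroxymethyl in place of methylsulfonyl on an aromatic carbon, para to a large group, and the change reads hydroxymethyl in place of methylsulfonyl on an aromatic carbon at that place. The unreadable step gives neither a size nor a direction for this change, so the expectation rests on the limit of compound 2 alone. No shift beyond the scatter can be argued, and the estimated change is a step that the limit leaves unreadable from compound 2 to compound 3 with a good chance that this assay again reports only a limit. For compound 3 the expected value is 4000 nM with an estimated range of 1000 nM to 15000 nM around it.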

Compound 3, solubility: < 5000 nM
Compound 3 ended at the assay's limit (the forecaster's own chance of this, stated with the estimate: 65%); the middle value does not contradict the limit.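

No step among compound 1, compound 2 and compound 3 can be read, since all three stand only at a limit in this assay: the limit of < 5000 nM in this assay, at which 3 of the 3 values shown sit.

The compounds shown leave open how soluble each one actually is, and whether hydrogen, methylsulfonyl or hydroxymethyl at that place changes the read-out at all.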